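The compounds below may be only part of what the source reports. "The series", "measured", "known", "first", "only" and "open" are said of these compounds alone.

Compound 1 `COc1ccc(C(=O)/C=C/c2ccc(N3CCCC3)cc2)c2c1C=CC(C)(C)O2`: 6180 nM
Compound 2 `COc1ccc(C(=O)/C=C/c2ccc([N+](=O)[O-])cc2)c2c1C=CC(C)(C)O2`: 7770 nM
Compound 3 `COc1ccc(C(=O)/C=C/c2ccccn2)c2c1C=CC(C)(C)O2`: 5400 nM

In a functional assay on K562 cells (Homo sapiens) for antiproliferative activity, read by MTT assay, with a stated time of 24 h (on this read-out lower numbers stand for stronger inhibition and higher numbers for weaker inhibition), compound 3 gives 5400 nM, the lowest of the three numbers, though all three lie within the scatter of one another. Compound 4 `COc1ccc(C(=O)/C=C/c2ccc(Cl)cc2)c2c1C=CC(C)(C)O2` has 4-chlorophenyl in place of pyridin-2-yl on a double-bonded chain carbon bound to a double-bonded chain carbon. Going by the values given here, the closest precedent changes the same place, a 1.4-fold lower number from compound 2 to compound 3 (0.16 log units; within the scatter). A change on an aromatic carbon, a 1.3-fold higher number from compound 1 to compound 2 (0.10 log units; within the scatter), also stayed within the scatter. No step beyond the scatter is therefore expected, and the estimate means a 1.1-fold higher number from compound 3 to compound 4 (0.05 log units; within the scatter). The estimated value for compound 4 is 6000 nM, with an expected range from 3500 nM to 10000 nM.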

Compound 4, half-maximal inhibitory concentration: > 10000 nM
Compound 4 ended at the assay's limit; the forecaster's own chance of this, stated with the estimate: 3%; middle value at least 1.6-fold (0.22 log units) away from the limit.
By their numbers in this assay, from the lowest: compounds 3, 1 and 2 (each within the scatter of the next). At a limit, above all of these: compound 4.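

In this assay compound 4 gives > 10000 nM, which is a limit of the assay and not a number. Only floors can be read from it: an at least 1.8-fold higher number from compound 3 to compound 4 (0.26 log units; that floor lies within the scatter), an at least 1.2-fold higher number from compound 2 to compound 4 (0.10 log units; that floor lies within the scatter) and an at least 1.6-fold higher number from compound 1 to compound 4 (0.20 log units; that floor lies within the scatter), and each floor stays within the scatter. At this place, 4-chlorophenyl in place of pyridin-2-yl is the first change shown to reach the limit, though no step beyond the scatter can yet be claimed. From the compounds shown here alone, whether an amine or a carboxylic acid in place of the chloro would bring the number back within the assay's range stays open.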